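The compounds below may be only part of what the source reports. "The series", "measured", "known", "first", "only" and "open" are said of these compounds alone.

Compound 1, `Nc1nc(Cl)c2ncn(Cc3ccccc3CCl)c2n1`: 23400 nM
Compound 2, `ClCc1cccc(Cn2cnc3nc(Cl)nc(Cl)c32)c1`: 3380 nM
Compound 3, `ClCc1ccc(Cn2cnc3c(Cl)nc(Cl)nc32)cc1`: 19500 nM

All three were measured in a functional assay on SF-295 cells (Homo sapiens) for cytotoxicity, read by sulforhodamine B assay, with a stated time of 48 h; on this read-out higher numbers stand for weaker inhibition of growth and lower numbers for stronger inhibition of growth. Compound 1 gives the highest of the three numbers; its gap to compound 3 lies within the usual scatter, while compound 2 sits beyond the scatter with the lower number. Compound 4, `ClCc1ccccc1Cn1cnc2c(Cl)ncnc21`, has not yet been measured. It differs from compound 1 in one place: hydrogen in place of amino on an aromatic carbon. Among the compounds with values here, no measured pair shows this exact change, so its size cannot be read from the data. Because compound 1 already stands at 23400 nM, the step is expected to be modest, a 1.3-fold higher number from compound 1 to compound 4 (0.11 log units; within the scatter), with no firm direction beyond the scatter. Compound 4 is therefore estimated at 30000 nM, within a range of 10000 nM to 90000 nM.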

Compound 4, concentration for total growth inhibition: 23400 nM
For compound 4 the middle estimate is 1.3-fold (0.11 log units) above the measured one, and the stated range covers the measured number.
By their numbers in this assay, from the lowest: compound 2; then compounds 3, 1 and 4 (each within the scatter of the next).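

In this assay, within the data shown here, putting hydrogen in place of amino on the aromatic carbon between two ring nitrogen atoms gives no change at the digits printed from compound 1 to compound 4 (within the scatter) and is the first single-place step in the set. With the rest of compound 1 held fixed, the amino group at this position therefore makes no visible difference to the number in this assay. No available evidence accounts for this result. The compounds shown leave open whether a different group on this carbon, such as methylamino, hydroxyl or methoxy, would shift the number beyond the scatter.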